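A few compounds are considered here, and "the series" means these few. Any claim that something is new, unique, unknown or untested is made for them only; others in the source may bear on it.

Compound 1 `Cc1ccc2c(c1)[n+]([O-])c(C#N)c(-c1ccco1)[n+]2[O-]` and compound 2 `COc1ccc2c(c1)[n+]([O-])c(C#N)c(-c1ccco1)[n+]2[O-]` share one core; compound 3 `Cc1ccc(-c2c(C#N)[n+]([O-])c3ccccc3[n+]2[O-])cc1` and compound 4 `COc1ccc(-c2c(C#N)[n+]([O-])c3ccccc3[n+]2[O-])cc1` share another. The difference between the two cores is not broken down here. In a physicochemical assay for lipophilicity, measured as octanol-water partition (on this read-out higher numbers stand for higher lipophilicity and lower numbers for lower lipophilicity), compound 1 gives 0.845, compound 2 gives 0.354 and compound 3 gives 2.09, the highest of the three. The change from compound 1 to compound 2 is methoxy in place of methyl on an aromatic carbon and it made a number 0.49 log units lower from compound 1 to compound 2 (beyond the scatter). The same kind of change, (methoxy in place of methyl on an aromatic carbon), leads from compound 3 to compound 4 and is made twice in all; the surroundings differ, one place being part of a fused or bridged system of two rings, meta to a fused ring and para to a fused ring, the other para to a large group. Compound 4 is not yet measured in this assay. For compound 4 a step like the earlier one is expected, a number 0.47 log units lower from compound 3 to compound 4 (beyond the scatter), because the same change made a number 0.49 log units lower from compound 1 to compound 2 (beyond the scatter). The estimate for compound 4 in this assay is 1.62, between 1.3 and 1.95.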

Compound 4, partition coefficient: 1.58
Estimate against measurement, compound 4: 0.04 log units above, and the stated range covers the measured number.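

In this assay methoxy in place of methyl on an aromatic carbon gives a number 0.51 log units lower from compound 3 to compound 4 (beyond the scatter), in the same direction and of much the same size as a number 0.49 log units lower from compound 1 to compound 2 (beyond the scatter), so the step carried over between these two cores although its surroundings differ. This rests on one pair per core and sets no general rule for the series or for any further core. Nothing at hand bears on why the two steps resemble each other.

On these data alone, whether an ethoxy group, an amine or a carboxylic acid in place of methyl would also give matching steps on both cores remains open. So does the size of the methoxy step at other places on either core.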